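Swapping a Benzodioxin Arm for a Methoxyphenyl Arm

This account rests on a few compounds, and the source may have more. Where it says the series, first, only, none or still open, it means among the compounds named here.

Three compounds have been measured in a functional assay on PANC-1 cells (Homo sapiens) for inhibition, read by MTT assay, with a stated time of 72 h; a lower number here means a stronger inhibitor of growth, a higher number a weaker inhibitor of growth:

Compound 2 `O=S(=O)(NCCCNCC1COc2ccccc2O1)c1cc(C(F)(F)F)cc(C(F)(F)F)c1` gives 3400 nM.
Compound 1 `O=S(=O)(NCCNCc1ccc(-c2ccccc2)cc1)c1cc(C(F)(F)F)cc(C(F)(F)F)c1` gives 4200 nM.
Compound 3 `CC(C)(C)c1ccc(CNCCNS(=O)(=O)c2cc(C(F)(F)F)cc(C(F)(F)F)c2)cc1` gives 13000 nM.

Compound 2 has the lowest number of the three, but compound 1 sits within the usual scatter of it, so the two cannot be ranked against each other. Compound 3 lies clearly higher than both.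

Compound 4 `COc1cccc(CNCCCNS(=O)(=O)c2cc(C(F)(F)F)cc(C(F)(F)F)c2)c1` differs from compound 2 in one place: 3-methoxyphenyl in place of 2,3-dihydro-1,4-benzodioxin-2-yl on a saturated chain carbon bound to an amine nitrogen. Within the data shown here, none of the measured compounds shows this exact change. Among the measured compounds shown here, the only measured single-point step, a 3.1-fold higher number from compound 1 to compound 3 (0.49 log units; beyond the scatter), swaps one group for another on the aromatic end of the shared core and gives a modest loss. That step concerns a different pair of groups, so it only suggests that changes at this end move the number by a modest amount at most.

Compound 4 is therefore estimated at 4500 nM, within a range from 2000 nM to 11000 nM. This estimate corresponds to an expected 1.3-fold higher number from compound 2 to compound 4 (0.12 log units; within the scatter), which would stay within the scatter.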

Compound 4, concentration for 50% growth inhibition: 10000 nM
Compound 4: the middle estimate sits 2.2-fold (0.35 log units) below what was measured, within the range that was stated.
By their numbers in this assay, from the lowest: compounds 2 and 1 (each within the scatter of the next); then compounds 4 and 3 (each within the scatter of the next).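

Among these compounds, compound 2 and compound 4 differ only at this position, so this is the first direct reading of the arm on the saturated chain carbon bound to the amine nitrogen. In this assay, 3-methoxyphenyl in place of 2,3-dihydro-1,4-benzodioxin-2-yl gives a 2.9-fold higher number from compound 2 to compound 4 (0.47 log units; beyond the scatter) and so this position does respond to the change, though only modestly. No measurement at hand explains this shift.

From the compounds shown here alone, it remains open whether the methoxy group contributes anything here, and a plain phenyl group at the same place would test that. A pyridine ring or a hydroxyl group in place of the methoxy group would show how far this position tolerates other groups.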